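A few compounds are considered here, and "the series" means these few. Any claim that something is new, unique, unknown or untested is made for them only; others in the source may bear on it.

Compounds measured in a functional assay (Nicotiana tabacum); on this read-out higher numbers stand for weaker inhibition and lower numbers for stronger inhibition:
- compound 1 `CCCNc1nc(SC)nc2ncccc12`: 270 nM
- compound 2 `CCCCNc1nc(SC)nc2ncccc12`: 270 nM
- compound 3 `CSc1nc(NC2CCC2)c2cccnc2n1`: 720 nM

Of these three, compound 3 carries the highest number, 720 nM, so it is the least potent in this assay. The next compound, compound 4 `CSc1nc(NC2CCCC2)c2cccnc2n1`, has cyclopentyl in place of cyclobutyl on a nitrogen on an aromatic ring.

Going by the values given here, no measured step makes this exact change, so the evidence is indirect. Going from an open chain to the cyclobutyl ring cost a modest amount, seen both in a 2.7-fold higher number from compound 1 to compound 3 (0.43 log units; beyond the scatter) and in a 2.7-fold higher number from compound 2 to compound 3 (0.43 log units; beyond the scatter). Lengthening the chain, in no change at the digits printed from compound 1 to compound 2 (within the scatter), had no effect beyond the scatter. These steps suggest that a single added carbon matters little here, and they give no sign that a larger ring would bring a large shift. In this assay, only a small move is therefore expected, leaning towards a lower number and possibly staying within the scatter. The expected step is a 1.4-fold lower number from compound 3 to compound 4 (0.16 log units; within the scatter). Compound 4 is estimated at 500 nM, with an expected range of 200 nM to 1200 nM.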

Compound 4, half-maximal inhibitory concentration: 490 nM
Compound 4: the middle estimate sits 1.0-fold (0.01 log units) above what was measured; the range from low to high includes it.
By their numbers in this assay, from the lowest: compounds 1, 2, 4 and 3 (each within the scatter of the next, the first and the last beyond it).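

In this assay, cyclopentyl in place of cyclobutyl on a nitrogen on an aromatic ring gives a 1.5-fold lower number from compound 3 to compound 4 (0.17 log units; within the scatter) and so does not separate the two rings. Compared with the open chains, cyclopentyl gives a 1.8-fold higher number from compound 2 to compound 4 (0.26 log units; within the scatter) for butyl and a 1.8-fold higher number from compound 1 to compound 4 (0.26 log units; within the scatter) for propyl, so unlike cyclobutyl, whose steps from those chains lie beyond the scatter, cyclopentyl cannot be told apart from either chain; a ring on this nitrogen therefore does not by itself set a compound apart from the open chains. No measurement at hand offers an explanation for these results.

Going by these compounds, whether cyclopropyl or cyclohexyl on this nitrogen would stay in the same range remains open. So does the question of where a branched chain such as isopropyl would fall relative to the rings and the open chains.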